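Ring amine substituent in a benzamide series: nitrobenzyl analogue

The source may hold more compounds than are shown below. What is called first, only, known or untested is meant among the compounds shown, and "the series" means these compounds.

Measured so far, in a functional assay on the whole organism for antagonist activity, with Mus musculus as the target; on this read-out lower numbers stand for an effect already at smaller amounts and higher numbers for an effect only at larger amounts of compound:
- compound 1 `COc1cc(N)c(Cl)cc1NC(=O)C1CCN(C2CCCC2)CC1` gives > 10 mg/kg, which is a limit of the assay and not a number.
- compound 2 `COc1cc(N)c(Cl)cc1NC(=O)C1CCN(Cc2ccc(Cl)cc2)CC1` gives 1.2 mg/kg.
- compound 3 `CCCN1CCC(C(=O)Nc2cc(Cl)c(N)cc2OC)CC1` gives > 10 mg/kg, which is again a limit and not a number.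

Compound 3 therefore stands only at the limit (the limit of > 10 mg/kg in this assay, at which 2 of the 3 values shown sit), and no number is known for it. The unmeasured compound 4 `COc1cc(N)c(Cl)cc1NC(=O)C1CCN(Cc2ccc([N+](=O)[O-])cc2)CC1` differs from compound 3 in one place: 4-nitrophenyl in place of ethyl on a saturated chain carbon bound to an amine nitrogen in a ring.

The measured steps that bear on this change are those at the same position. The step of an at least 8.3-fold higher number from compound 2 to compound 3 (0.92 log units; beyond the scatter) runs in the opposite direction, from an aryl group to a short chain, and its size is only a lower bound. The step of an at least 8.3-fold lower number from compound 1 to compound 2 (0.92 log units; beyond the scatter) likewise shows that a 4-chlorobenzyl group on the ring nitrogen gives a markedly lower number than a small alkyl group. The step that the two limits leave unreadable from compound 1 to compound 3 cannot be read. Among the measured compounds shown here, a nitro group on the aryl ring has no measured counterpart here, so its own contribution is unknown.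

For compound 4 the expectation is therefore a number clearly below the limit, estimated at 2 mg/kg, with a range from 0.5 mg/kg to 8 mg/kg. This corresponds to an expected step of an at least 5.0-fold lower number from compound 3 to compound 4 (0.69 log units; beyond the scatter) in this assay.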

Compound 4, dose for half-maximal effect: > 4 mg/kg
Compound 4: a limit, no number (the forecaster's own chance of this, stated with the estimate: 20%); middle value at least 2.0-fold (0.30 log units) from the limit.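

In this assay compound 4 gives > 4 mg/kg, which is a limit and not a number. With nitro in place of chloro on an aromatic carbon, the change gives an at least 3.3-fold higher number from compound 2 to compound 4 (0.52 log units; beyond the scatter), so the low number of compound 2 does not carry over to every para-free description of an aryl group at this place: among the two aryl compounds shown, only the 4-chlorobenzyl compound reaches a number, and the substituent on the aromatic ring decides the outcome here. The step between compound 3 and compound 4 cannot be read, as both values are limits, so the effect of 4-nitrophenyl in place of ethyl on a saturated chain carbon bound to an amine nitrogen in a ring remains unsettled.

As far as these compounds go, how far beyond its limit compound 4 lies, and whether it differs at all from compound 3, stays open. Also open, from the compounds shown here alone, is whether the chloro group itself is required, a question that unsubstituted benzyl, 4-fluorobenzyl or 4-methoxybenzyl on the amine nitrogen in the ring would address.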